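Swapping the sulfonyl aryl ring in a quinoline series

The compounds below may be only part of what the source reports. "The series", "measured", "known", "first", "only" and "open" are said of these compounds alone.

Of the compounds shown here, three have been tested in an assay on isolated protein for displacement of a labelled ligand from metabotropic glutamate receptor 5 (Homo sapiens), with a stated time of 60 min, tested at 1 uM; a higher number here means more inhibition at the concentration tested (going by the name of the read-out), a lower number less inhibition. Compound 1 `CC1CCN(c2c(S(=O)(=O)c3cc(F)cc(F)c3)cnc3ccc(Cl)cc23)CC1` gives 93%. Compound 2 `CC1CCN(c2c(S(=O)(=O)c3ccc(Cl)c(Cl)c3)cnc3cc(Cl)ccc23)CC1` gives 89%, and compound 3 `CC1CCN(c2c(S(=O)(=O)c3ccc(Cl)c(Cl)c3)cnc3cc(F)ccc23)CC1` gives 94%. The number for compound 3 is the largest of the three, but the gap to compound 1 and the gap to compound 2 both lie within the scatter, so the three are not told apart. Among the measured compounds shown here, the only single-point step measured, a number 5 percentage points higher from compound 2 to compound 3 (within the scatter), concerns the halogen on the shared core and not the sulfonyl aryl ring.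

Compound 4 `Cc1ccc(S(=O)(=O)c2cnc3cc(F)ccc3c2N2CCC(C)CC2)cc1` differs from compound 3 by 4-methylphenyl in place of 3,4-dichlorophenyl on a sulfonyl sulfur. For the measured compounds named here, no measured step touches this part of the molecule; compound 1 and compound 3 carry different rings on the sulfonyl sulfur but also differ on the core, so their values show only that both rings give high inhibition. The loss of both chlorines is a larger change than any measured here, so a modest drop is expected, a number 14 percentage points lower from compound 3 to compound 4 (beyond the scatter). Compound 4 is estimated at 80%, with a range from 60% to 95%.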

Compound 4, a percentage reported as inhibition, at one concentration (the size of the read-out at that concentration, not a potency): 88%
Compound 4: the middle estimate sits 8 percentage points below what was measured; the range from low to high includes it.
By their numbers in this assay, from the lowest: compounds 4, 2, 1 and 3 (each within the scatter of the next).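

Among the compounds shown here, with the shared core held fixed, this assay gives a number 6 percentage points lower from compound 3 to compound 4 (within the scatter), the first measured step that changes the ring on the sulfonyl sulfur. Compound 4 carries no chlorine on this ring and still gives high inhibition, so at this single concentration 4-methylphenyl and 3,4-dichlorophenyl are not told apart, and the chlorines on this ring are not required for a high reading. No measurement shown here offers an explanation for this result.

As far as these compounds go, a reading at one concentration gives no potency, so any difference in potency between compound 3 and compound 4 remains unknown. Also open, from the compounds shown here alone, is how this position responds to an unsubstituted phenyl ring, a pyridine ring, or a phenyl ring bearing a carboxylic acid or an amine.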